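This account rests on a few compounds, and the source may have more. Where it says the series, first, only, none or still open, it means among the compounds named here.

Measured so far, in an ADME assay for metabolic stability, read by LC-MS, with a stated time of 3 h, at pH 6.5, tested at 50 uM; on this read-out lower numbers stand for a less stable compound and higher numbers for a more stable compound:
compound 1, `CCOC(=O)C1=C(S[C@@H]2CN[C@H](C(=O)Nc3cccc(C(=O)OCC)c3)C2)[C@H](C)[C@@H]2[C@@H]([C@@H](C)OC(C)=O)C(=O)N12`, gives > 95%, which is a limit of the assay rather than a number.
Compound 2, `CCOC(=O)C1=C(S[C@H]2C[C@@H](C(=O)Nc3cccc(C(=O)OCC)c3)N(C(=O)OCc3oc(=O)oc3C)C2)[C@H](C)[C@@H]2[C@@H]([C@@H](C)O)C(=O)N12`, gives > 95%, likewise a limit of the assay.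

Compound 2 thus stands at the top of what this assay can report, because of the limit of > 95% in this assay, at which 2 of the 2 values shown sit. Compound 3, `CCOC(=O)C1=C(S[C@@H]2CN[C@H](C(=O)Nc3cccc(C(=O)OCC)c3)C2)[C@H](C)[C@@H]2[C@@H]([C@@H](C)O)C(=O)N12`, differs from compound 2 by a hydrogen atom in place of a group of 11 heavy atoms (6 carbon, 5 oxygen; one five-membered aromatic ring with 2 hetero atoms), on an amine nitrogen in a ring. Compound 1 also carries hydrogen on that amine nitrogen and sits at the same limit, so no change beyond the usual scatter is expected. Compound 3 is expected at 95%, between 85% and 100%. The step expected is a number no higher from compound 2 to compound 3 (the limit leaves the size open).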

Compound 3, percent of the compound remaining: > 95%
Compound 3: no number, only a limit; the forecaster's own chance of this, stated with the estimate: 70%; the middle value lies on the limit itself.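

Among these compounds, no step to compound 3 can be read from compound 1 or compound 2, since all three compounds sit at the same limit: the limit of > 95% in this assay, at which 3 of the 3 values shown sit. As far as these compounds go, what the group of 11 heavy atoms on the amine nitrogen, or the acetyl on the oxygen, does to the result in this assay stays open.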